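Clearance of a biaryl replacing the alkyne arm

A few compounds are considered here, and "the series" means these few. Any claim that something is new, unique, unknown or untested is made for them only; others in the source may bear on it.

Measured compounds:
compound 1, `COCC#Cc1cc(C(O)(C(F)(F)F)C(F)(F)F)cnc1N1CCN(S(=O)(=O)c2ccc(N)nc2)CC1`, 399 mL.min-1.g-1
compound 2, `Nc1ccc(S(=O)(=O)N2CCN(c3ncc(C(O)(C(F)(F)F)C(F)(F)F)cc3C#CCCO)CC2)cn1`, 68 mL.min-1.g-1
compound 3, `Nc1ccc(S(=O)(=O)N2CCN(c3ncc(C(O)(C(F)(F)F)C(F)(F)F)cc3-c3ccccc3O)CC2)cn1`, 125 mL.min-1.g-1

In an ADME assay (liver) for metabolic stability, with Liver microsome (Rattus norvegicus) as the target, using microsomes and NADPH, with a stated time of 30 min, tested at 1 uM (a lower number here means slower removal, a higher number faster removal of the compound), compound 1 gives the highest of the three numbers; compound 3 is nearest to it and compound 2 furthest, with both steps beyond the scatter, as a 3.2-fold lower number from compound 1 to compound 3 (0.50 log units; beyond the scatter) and a 5.9-fold lower number from compound 1 to compound 2 (0.77 log units; beyond the scatter) show. Compound 4, `CS(=O)(=O)Nc1cccc(-c2cc(C(O)(C(F)(F)F)C(F)(F)F)cnc2N2CCN(S(=O)(=O)c3ccc(N)nc3)CC2)c1`, differs from compound 1 in one place: 3-(methanesulfonamido)phenyl in place of 3-methoxyprop-1-yn-1-yl on an aromatic carbon. Among the compounds with values here, the step that bears most on this change is the one from compound 1 to compound 3, in which a ring also takes the place of the alkyne arm, giving a 3.2-fold lower number from compound 1 to compound 3 (0.50 log units; beyond the scatter). Between compound 2 and compound 3 the difference is a 1.8-fold higher number from compound 2 to compound 3 (0.26 log units; within the scatter), so the two compounds without the methoxy-bearing alkyne sit close to each other in this assay. By analogy to compound 3, compound 4 is expected to show a lower number than compound 1, with an estimated step of a 3.1-fold lower number from compound 1 to compound 4 (0.49 log units; beyond the scatter). For compound 4 the estimated value is 130 mL.min-1.g-1, within a range from 50 mL.min-1.g-1 to 340 mL.min-1.g-1.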

Compound 4, intrinsic clearance in microsomes: 81 mL.min-1.g-1
Beside the measured number, compound 4's estimate is 1.6-fold (0.21 log units) above it, within the range that was stated.
By their numbers in this assay, from the lowest: compounds 2, 4 and 3 (each within the scatter of the next); then compound 1.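

In this assay, the much larger 3-(methanesulfonamido)phenyl group on this aromatic carbon still gives a number well under that of compound 1 (a 4.9-fold lower number from compound 1 to compound 4 (0.69 log units; beyond the scatter)), so the drop seen with the 2-hydroxyphenyl group also holds for a second aryl group with a different substituent. Within the data shown here, compound 4 stays within the scatter of both other replacements (a 1.5-fold lower number from compound 3 to compound 4 (0.19 log units; within the scatter); a 1.2-fold higher number from compound 2 to compound 4 (0.08 log units; within the scatter)), which shows that the 11 heavy atoms and the added sulfur do not separate it from compound 3 or from compound 2, the one member of this group that keeps an alkyne arm. Nothing available explains why these three compounds sit together.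

The compounds shown leave open whether an unsubstituted phenyl group would stay at this level. As far as these compounds go, it is also open how an amine or a carboxylic acid in place of the methanesulfonamido group would behave.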